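The source may hold more compounds than are shown below. What is called first, only, known or untested is meant among the compounds shown, and "the series" means these compounds.

Going by the values given here, compound 2 `CN(Cc1cc(C(F)(F)F)cc(C(F)(F)F)c1)C(=O)c1c(OCCCC2CCCCC2)c2ccccc2n(C)c1=O` is the only compound here with a measured number in an ADME assay for inhibition of phosphatidylcholine:ceramide cholinephosphotransferase 1 (Homo sapiens), read by mass spectrometry, with stated times of 60 min and 30 min; a higher number here means a weaker inhibitor, a lower number a stronger inhibitor: compound 2 gives 14000 nM. Compound 1 `CCCOc1c(C(=O)N(C)Cc2cc(C(F)(F)F)cc(C(F)(F)F)c2)c(=O)n(C)c2ccccc12` reaches only the limit of the assay, and in this assay compound 1 gives > 100000 nM, a limit rather than a number. Among the compounds with values here, the single measured step, an at least 7.1-fold lower number from compound 1 to compound 2 (0.85 log units; beyond the scatter), therefore rests on (the limit of > 100000 nM in this assay, at which 1 of the 2 values shown sits). Compound 3 `CN(Cc1cc(C(F)(F)F)cc(C(F)(F)F)c1)C(=O)c1c(OCCCC(F)(F)F)c2ccccc2n(C)c1=O` differs from compound 2 by trifluoromethyl in place of cyclohexyl on a saturated chain carbon, three bonds along the chain from an oxygen on an aromatic ring. Within the data shown here, the only step that bears on this position is an at least 7.1-fold lower number from compound 1 to compound 2 (0.85 log units; beyond the scatter), and no measured compound carries trifluoromethyl there, so the direction is read from that one step alone: the sole group other than cyclohexyl seen at this carbon, hydrogen, went with a weaker inhibitor. Compound 3 is therefore expected to give a higher number, a 2.9-fold higher number from compound 2 to compound 3 (0.46 log units; beyond the scatter), and may reach the limit again. The estimate for compound 3 is 40000 nM, with a range from 12000 nM to 120000 nM.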

Compound 3, half-maximal inhibitory concentration: 25000 nM
For compound 3 the middle estimate is 1.6-fold (0.20 log units) above the measured one, within the range that was stated.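

Replacing the cyclohexyl with trifluoromethyl on this chain carbon makes no change beyond the scatter (a 1.8-fold higher number from compound 2 to compound 3 (0.25 log units; within the scatter)), so compound 2 and compound 3 cannot be ranked against each other. The ring is therefore not required at this carbon, since a trifluoromethyl group with no ring also stands apart from the hydrogen of compound 1 (an at least 4.0-fold lower number from compound 1 to compound 3 (0.60 log units; beyond the scatter)). Compound 1 remains a limit and not a number, so this second step, like the earlier one, has only a lower bound on its size: (the limit of > 100000 nM in this assay, at which 1 of the 3 values shown sits).

The compounds shown leave open whether a hydroxyl group, an amine or a carboxylic acid on this carbon would fit the same picture. They also leave open how a phenyl ring or a longer chain ending in cyclohexyl would read.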